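Fluoro for methyl on the fused ring of compound 2

The compounds below may be only part of what the source reports. "The series", "measured", "known", "first", "only" and "open" are said of these compounds alone.

Measured compounds:
compound 1 `Cc1ccc2nc(C(=O)Nc3c(F)cc(-c4cccc(F)c4)cc3F)c(C)c(O)c2c1` — 17.9%
compound 2 `Cc1ccc2nc(C(=O)Nc3c(F)cc(-c4cccc(F)c4)cc3F)c(C)c(C(=O)O)c2c1` — 19.2%

In a functional assay on A-375 cells (Homo sapiens) for antiproliferative activity, read by MTT assay, with a stated time of 24 h, tested at 11.11 ug/mL (a higher number here means a stronger effect of the compound at the concentration tested, a lower number a weaker effect), compound 1 gives 17.9% and compound 2 gives 19.2%. Compound 2 holds the larger of the two numbers, but the step of a number 1.3 percentage points higher from compound 1 to compound 2 (within the scatter) lies within the scatter, so the two compounds are not separated by this assay; the change from hydroxy to carboxy on the core left the read-out essentially unchanged.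

Compound 3 `Cc1c(C(=O)Nc2c(F)cc(-c3cccc(F)c3)cc2F)nc2ccc(F)cc2c1C(=O)O` differs from compound 2 by fluoro in place of methyl on an aromatic carbon. Going by the values given here, no measured step touches that part of the core: the only step in hand, a number 1.3 percentage points higher from compound 1 to compound 2 (within the scatter), concerns a different group and was itself within the scatter. There is therefore no measured basis for expecting a shift beyond the scatter in either direction; the expected step is a number 0.2 percentage points lower from compound 2 to compound 3 (within the scatter), which is essentially none. Compound 3 is thus estimated to come out near compound 2, at 19%, with a range from 8% to 30% to allow for the scatter and for the untested position.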

Compound 3, a percentage reported as inhibition, at one concentration (the size of the read-out at that concentration, not a potency): 36.3%
Compound 3: the middle estimate sits 17.3 percentage points below what was measured, outside the stated range (above it).
By their numbers in this assay, from the lowest: compounds 1 and 2 (each within the scatter of the next); then compound 3.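

In this assay, going by these compounds alone, the aromatic carbon of the six-membered aromatic ring of carbon only is the first place where a single change moves the read-out beyond the scatter: fluoro in place of methyl gives a number 17.1 percentage points higher from compound 2 to compound 3 (beyond the scatter), whereas the only earlier change, carboxy in place of hydroxy elsewhere on the shared core, gave a number 1.3 percentage points higher from compound 1 to compound 2 (within the scatter), which stays within it. The new step is also a small one by the computed counts, since one heavy atom leaves, one enters, and neither group brings a ring, a hydrogen-bond donor, a hydrogen-bond acceptor or a net charge, so those counts do not separate methyl from fluoro. Nothing at hand accounts for the size of the step.

The compounds shown leave open whether the higher number follows from fluoro itself or from the loss of methyl, which chloro or a plain hydrogen on the same carbon would help to separate. Also open, on these data alone, is whether hydroxy could replace carboxy on compound 3 with as little effect as it has alongside methyl, and how an amine on that ring carbon would compare.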